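The source may hold more compounds than are shown below. What is called first, only, known or untested is meant among the compounds shown, and "the series" means these compounds.

Three compounds have been measured in a functional assay on HL-60 cells (Homo sapiens) for antiproliferative activity, read by MTT assay, with a stated time of 72 h; a higher number here means a weaker inhibitor, a lower number a stronger inhibitor:

compound 1 `CCC(=O)N(C)c1ccc2[nH]c(-c3n[nH]c4ccccc34)cc2n1`, giving 6130 nM
compound 2 `CN(C(=O)c1ccccc1)c1ccc2[nH]c(-c3n[nH]c4ccccc34)cc2n1`, giving 4850 nM
compound 3 `CN(c1ccc2[nH]c(-c3n[nH]c4ccccc34)cc2n1)S(=O)(=O)c1ccc(Cl)cc1`, giving 770 nM

Compound 3 has the lowest number of the three. The two measured steps that reach it, an 8.0-fold lower number from compound 1 to compound 3 (0.90 log units; beyond the scatter) and a 6.3-fold lower number from compound 2 to compound 3 (0.80 log units; beyond the scatter), each exchange a carbonyl-bearing group on the ring nitrogen for the sulfonyl group, and both lower the number beyond the scatter. Compound 4 `CN(C(=O)Nc1ccccc1)c1ccc2[nH]c(-c3n[nH]c4ccccc34)cc2n1` differs from compound 3 by phenylcarbamoyl in place of (4-chlorophenyl)sulfonyl on a nitrogen on an aromatic ring, which puts a carbonyl-bearing group back in that place. Both measured steps therefore bear on it in reverse, and an increase in this assay beyond the scatter is expected, roughly undoing them. For compound 4 the expected step is a 5.2-fold higher number from compound 3 to compound 4 (0.72 log units; beyond the scatter), giving an estimated 4000 nM, within a range of 1500 nM to 12000 nM.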

Compound 4, half-maximal inhibitory concentration: 8.3 nM
For compound 4 the middle estimate is 480-fold (2.68 log units) above the measured one, and the stated range ends above it.
By their numbers in this assay, from the lowest: compound 4; then compound 3; then compounds 2 and 1 (each within the scatter of the next).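

In this assay the carbonyl group alone does not set the number at this nitrogen; what sits on the carbonyl carbon does. Anilino in place of phenyl gives a 580-fold lower number from compound 2 to compound 4 (2.77 log units; beyond the scatter) and anilino in place of ethyl gives a 740-fold lower number from compound 1 to compound 4 (2.87 log units; beyond the scatter) at that carbon, and phenylcarbamoyl in place of (4-chlorophenyl)sulfonyl gives a 93-fold lower number from compound 3 to compound 4 (1.97 log units; beyond the scatter) on the nitrogen itself. Nothing measured here explains these large steps.

Still open, as far as these compounds go, is whether the gain depends on the anilino nitrogen with its hydrogen or on the phenyl ring it carries. Compounds with methylamino or dimethylamino on that carbonyl carbon would help separate the two.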